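The source may report more compounds than this note shows. Statements on the series, on what has been measured and on what is new or still open speak of the compounds shown alone.

In an assay on CHO cells for inhibition of Amine oxidase [copper-containing] 3 (Homo sapiens), read by spectrophotometry, with stated times of 30 min and 1 h (a higher number here means a weaker inhibitor, a lower number a stronger inhibitor), compound 3 `CC(=O)Nc1nc(CCc2ccc(NC3=NCCN3)cc2)cs1` gives 3000 nM, the lowest of the two numbers recorded, although its gap to compound 2 is within the scatter. Compound 2 `CC(=O)Nc1nc(CCc2ccc(NC3=NCCS3)cc2)cs1` gives 3500 nM in this assay. Compound 1 `CC(=O)Nc1nc(CCc2ccc(N)cc2)cs1` gives only a limit in this assay, > 100000 nM; this is the limit of > 100000 nM in this assay, at which 1 of the 3 values shown sits. The measured steps are an at least 28-fold lower number from compound 1 to compound 2 (1.45 log units; beyond the scatter), an at least 33-fold lower number from compound 1 to compound 3 (1.52 log units; beyond the scatter) and a 1.2-fold lower number from compound 2 to compound 3 (0.07 log units; within the scatter). Compound 4 `CC(=O)Nc1nc(CCc2ccc(NC=N)cc2)cs1` differs from compound 3 in that (a group of 2 heavy atoms (1 carbon, 1 nitrogen; no ring) in place of a group of 5 heavy atoms (3 carbon, 2 nitrogen; one five-membered non-aromatic ring with 2 hetero atoms), on a nitrogen on an aromatic ring). The two large steps bear on this change, since both show that a five-membered non-aromatic ring with 2 hetero atoms on that nitrogen, in place of a hydrogen atom, carries the whole of the measured inhibition; compound 4 keeps a double bond outside aromatic rings and a hydrogen-bond donor on that nitrogen but loses the ring. A step weaker than compound 3, yet well short of the limit seen for compound 1, is therefore expected, a 2.7-fold higher number from compound 3 to compound 4 (0.43 log units; beyond the scatter). Compound 4 is estimated at 8000 nM in this assay, within a range from 2000 nM to 40000 nM.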

Compound 4, half-maximal inhibitory concentration: 730 nM
Compound 4: the middle estimate sits 11-fold (1.04 log units) above what was measured; measured number outside the range, below it.
By their numbers in this assay, from the lowest: compound 4; then compounds 3 and 2 (each within the scatter of the next). At a limit, above all of these: compound 1.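

The five-membered ring on the nitrogen is therefore not required for inhibition, since the open group of 2 heavy atoms does better than either ring, with a 4.1-fold lower number from compound 3 to compound 4 (0.61 log units; beyond the scatter) and a 4.8-fold lower number from compound 2 to compound 4 (0.68 log units; beyond the scatter). Within the data shown here, the earlier compounds showed only that a ring in place of a hydrogen atom mattered, whereas an at least 130-fold lower number from compound 1 to compound 4 (2.13 log units; beyond the scatter) shows that this much smaller group is enough on its own. That last step is a minimum rather than an exact size, as the value for compound 1 is a limit and not a number: the limit of > 100000 nM in this assay, at which 1 of the 4 values shown sits.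

The compounds shown cannot separate the loss of the ring from the reduction in the number of heavy atoms, as the two change together. Going by these compounds, how a guanidine, an acetyl group or a methyl group on that nitrogen would behave in this assay remains open.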